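This account rests on a few compounds, and the source may have more. Where it says the series, first, only, none or still open, it means among the compounds named here.

Working notes on the series. Compound 1 `COc1cc(C(=O)/C=C/c2cc(-c3cc(OC)c(OC)c(OC)c3)n3nc(-c4ccccc4)cc3n2)cc(OC)c1OC` and compound 2 `COc1cc(-c2cc(/C=C/C(=O)c3ccc(C)c(C)c3)nc3cc(-c4ccccc4)nn23)cc(OC)c1OC` share one core and differ only in the aryl group on the carbonyl carbon of the enone chain. In a functional assay on DU-145 cells (Homo sapiens) for antiproliferative activity, read by MTT assay, with a stated time of 24 h (a higher number here means a weaker inhibitor, a lower number a stronger inhibitor), compound 1 gives 34900 nM. In this assay, within the data shown here, compound 2 gives 15400 nM, the lowest of the two numbers measured so far; the only step on record, a 2.3-fold lower number from compound 1 to compound 2 (0.36 log units; beyond the scatter), is a modest one and is the sole guide to how this aryl position responds.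

Compound 3 `COc1cc(-c2cc(/C=C/C(=O)c3ccc(Cl)cc3)nc3cc(-c4ccccc4)nn23)cc(OC)c1OC` extends the same position: 4-chlorophenyl in place of 3,4-dimethylphenyl on a carbonyl carbon. Among the measured compounds shown here, no measured pair shows a 4-chlorophenyl at this carbonyl, so the only comparison is the step from compound 1 to compound 2, which was modest and beyond the scatter. The change into compound 3 is a smaller rearrangement of the same aryl ring than that step, so a step no larger than the scatter is expected, in no firm direction. On that basis compound 3 is estimated at 14000 nM in this assay, with a range from 5000 nM to 40000 nM, which corresponds to an expected step of a 1.1-fold lower number from compound 2 to compound 3 (0.04 log units; within the scatter).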

Compound 3, half-maximal inhibitory concentration: 29300 nM
Compound 3: the middle estimate sits 2.1-fold (0.32 log units) below what was measured, within the range that was stated.
By their numbers in this assay, from the lowest: compounds 2, 3 and 1 (each within the scatter of the next, the first and the last beyond it).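

In this assay the change from 3,4-dimethylphenyl to 4-chlorophenyl on the carbonyl carbon gives a 1.9-fold higher number from compound 2 to compound 3 (0.28 log units; within the scatter) and so stays inside the usual spread of repeat measurements; the comparison with the 3,4,5-trimethoxyphenyl group gives a 1.2-fold lower number from compound 1 to compound 3 (0.08 log units; within the scatter) and stays inside it as well. Among these compounds, compound 3 therefore cannot be separated from either compound 2 or compound 1, and the 4-chlorophenyl group does not widen the span set by a 2.3-fold lower number from compound 1 to compound 2 (0.36 log units; beyond the scatter), which remains the only step at this position beyond the scatter. No measurement accompanies these values that could account for any difference among the three aryl groups.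

The compounds shown leave open whether the position responds at all to a group much unlike these substituted phenyl rings, such as a pyridyl ring or a phenyl ring carrying a dimethylamino group or a carboxylic acid. They also leave open how an unsubstituted phenyl ring or a 4-methylphenyl group would compare on the same carbonyl carbon.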